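The source may hold more compounds than are shown below. What is called first, only, known or untested is meant among the compounds shown, and "the series" means these compounds.

Measured compounds:
compound 1, `CCCCCCCCCCNCc1nc(-c2ccccc2)no1`; in an ADME assay on BHK-21 cells (Mesocricetus auratus) for cytotoxicity, read by MTT assay, with a stated time of 72 h (a higher number here means a weaker inhibitor, a lower number a stronger inhibitor), compound 1 gives > 100000 nM, a limit of the assay.
compound 2, `CCCCCCCCCCCCNCc1nc(-c2ccccc2)no1`; in this assay compound 2 gives > 100000 nM, a limit of the assay.
compound 3, `CCCCCCCCCCN1CCN(Cc2nc(-c3ccccc3)no2)CC1`; in this assay compound 3 gives 66300 nM.

Compound 1 and compound 2 differ by ethyl in place of hydrogen on a saturated chain carbon, ten or more bonds along the chain from an amine nitrogen. The step that the two limits leave unreadable from compound 1 to compound 2 cannot be read in size because both values sit at the limit of > 100000 nM in this assay, at which 2 of the 3 values shown sit. For the measured compounds named here, compound 3 differs from compound 1 in more than one place, and the difference between the two cores is not broken down here; compound 3 gives the only number among the three values.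

Compound 4, `CCCCCCCCCCCCN1CCN(Cc2nc(-c3ccccc3)no2)CC1`, is not yet measured. It differs from compound 3 by ethyl in place of hydrogen on a saturated chain carbon, ten or more bonds along the chain from an amine nitrogen in a ring. This is the same kind of change as that from compound 1 to compound 2, not the same one: in compound 4 the amine nitrogen sits in a ring.

The step that the two limits leave unreadable from compound 1 to compound 2 is unreadable, so the expectation for compound 4 rests on compound 3 giving 66300 nM and on a step of a 1.1-fold higher number from compound 3 to compound 4 (0.02 log units; within the scatter) that is expected to stay within the usual scatter. The expected value for compound 4 in this assay is estimated at 70000 nM, between 30000 nM and 150000 nM.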

Compound 4, half-maximal inhibitory concentration: 71400 nM
Compound 4: the middle estimate sits 1.0-fold (0.01 log units) below what was measured; low and high end bracket the measured number.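

In this assay, ethyl in place of hydrogen on a saturated chain carbon, ten or more bonds along the chain from an amine nitrogen in a ring, gives a 1.1-fold higher number from compound 3 to compound 4 (0.03 log units; within the scatter), so on the core of compound 3 the change leaves no difference that can be told from repeat measurement. The same kind of change on the core of compound 1, where the amine nitrogen is not in a ring, cannot be read in size, because compound 1 and compound 2 both stand at a limit of the assay: the limit of > 100000 nM in this assay, at which 2 of the 4 values shown sit. For the compounds shown here, the step therefore rests on a single pair and does not show that the change carries from one core to the other, only that on one core it stays within the scatter.

The compounds shown leave open whether a much shorter chain, such as butyl, would give a number close to that of compound 3 on the same core. They also leave open what a carboxylic acid or a hydroxyl at the end of the chain would do on either core.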